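Swapping Cyclohexyl for Thiophen-2-yl on the Amide Carbonyl

This account rests on a few compounds, and the source may have more. Where it says the series, first, only, none or still open, it means among the compounds named here.

Measured compounds:
Compound 1, `CN1CCC(c2c[nH]c3cnc(NC(=O)c4ccc(F)cc4)cc23)CC1` — 13 nM
Compound 2, `CN1CCC(c2c[nH]c3ccc(NC(=O)C4CCCCC4)nc23)CC1` — 20 nM
Compound 3, `CN1CCC(c2c[nH]c3ccc(NC(=O)c4cccc(F)c4)nc23)CC1` — 11 nM

All three compounds were tested in an assay for binding affinity to 5-hydroxytryptamine receptor 1F (Homo sapiens), read by radioligand binding; on this read-out higher numbers stand for weaker inhibition and lower numbers for stronger inhibition. Compound 2 carries a cyclohexyl group on its carbonyl carbon and gives 20 nM. Compound 1 gives 13 nM and compound 3 gives 11 nM; the gaps between compound 2 and each of the other two are within the usual scatter, so the three numbers sit in one narrow band and none can be called stronger or weaker than another.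

The unmeasured compound 4, `CN1CCC(c2c[nH]c3ccc(NC(=O)c4cccs4)nc23)CC1`, differs from compound 2 in one place: thiophen-2-yl in place of cyclohexyl on a carbonyl carbon. Among the compounds with values here, the one measured step that resembles this is the replacement of the same cyclohexyl by a ring of another kind, a 1.8-fold lower number from compound 2 to compound 3 (0.26 log units; within the scatter). Since that change stayed within the scatter, a change of cyclohexyl to thiophen-2-yl at the same position is expected to do the same, with no clear movement in either direction.

Compound 4 is therefore expected to give about 13 nM in this assay, with a range from 5 nM to 35 nM. This estimate amounts to a step of a 1.5-fold lower number from compound 2 to compound 4 (0.19 log units; within the scatter), expected to remain within the scatter.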

Compound 4, inhibition constant: 7.1 nM
Beside the measured number, compound 4's estimate is 1.8-fold (0.26 log units) above it; low and high end bracket the measured number.
By their numbers in this assay, from the lowest: compounds 4, 3, 1 and 2 (each within the scatter of the next, the first and the last beyond it).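

In this assay, this carbonyl position now shows a step that clears the usual scatter: replacing cyclohexyl with thiophen-2-yl gives a 2.8-fold lower number from compound 2 to compound 4 (0.45 log units; beyond the scatter), whereas the earlier replacement with 3-fluorophenyl gave a 1.8-fold lower number from compound 2 to compound 3 (0.26 log units; within the scatter) and could not be told apart from repeat-measurement noise. Compound 3 and compound 4 still cannot be separated, since thiophen-2-yl in place of 3-fluorophenyl gives a 1.5-fold lower number from compound 3 to compound 4 (0.19 log units; within the scatter), so the result sets the thiophen-2-yl compound apart from the cyclohexyl compound but not from the 3-fluorophenyl compound. Nothing in the available data explains the gain seen with thiophen-2-yl.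

The compounds shown leave open whether this gain is particular to thiophen-2-yl or would also appear with a related ring on the same carbonyl carbon, such as thiophen-3-yl, furan-2-yl or pyridin-2-yl. They also leave open how far the position tolerates a group of a different kind, such as a short alkyl chain or an amine, in place of these rings.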